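Trifluoromethyl in Place of Hydrogen: What to Expect for Compound 4

The source may report more compounds than this note shows. Statements on the series, on what has been measured and on what is new or still open speak of the compounds shown alone.

In a functional assay on HL-60 cells (Homo sapiens), read by calcium flux (on this read-out lower numbers stand for an effect already at smaller amounts and higher numbers for an effect only at larger amounts of compound), compound 1 `CCc1cc(Cc2cccc(OC)c2)c(=O)n(CC(=O)Nc2ccc(I)cc2)n1` gives > 50000 nM, which is a limit of the assay rather than a number.
In this assay compound 2 `Cc1cc(Cc2ccccc2)c(=O)n(CC(=O)Nc2ccc(Br)cc2)n1` gives > 50000 nM, again a limit.
In this assay compound 3 `Cc1cc(Cc2ccccc2)c(=O)n(CC(=O)Nc2ccc(F)cc2)n1` gives > 50000 nM, also a limit.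

Compound 2 therefore stands where every measured compound stands: at the limit of > 50000 nM in this assay, at which 3 of the 3 values shown sit. Within the data shown here, the one measured step between neighbours, a step that the two limits leave unreadable from compound 2 to compound 3, cannot be read, since both ends are limits and no number lies between them.

Compound 4 `Cc1cc(Cc2ccc(C(F)(F)F)cc2)c(=O)n(CC(=O)Nc2ccc(Br)cc2)n1` differs from compound 2 by trifluoromethyl in place of hydrogen on an aromatic carbon. No measured step touches this change, and the only step shown gives no readable size to lean on. What the three compounds do show is that the shared core, with varied groups on both outer rings, has not reached a measurable effect in this assay.

On that footing compound 4 is expected to remain at the limit as well, with an estimated value of 80000 nM, ranging from 20000 nM to 300000 nM. The expected step from compound 2 to compound 4 is a step that the limit leaves unreadable from compound 2 to compound 4, none beyond the scatter.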

Compound 4, half-maximal effective concentration: > 50000 nM
Compound 4: only a limit was reported; the forecaster's own chance of this, stated with the estimate: 80%; the middle value lies beyond the limit too.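

Among these compounds, compound 2 and compound 4 each give only a limit, so no step between them can be read, and trifluoromethyl in place of hydrogen has no readable size. The compounds shown leave open what change to the shared core, if any, would bring a measurable effect.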